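A few compounds are considered here, and "the series" means these few. Any claim that something is new, unique, unknown or untested is made for them only; others in the source may bear on it.

Three compounds have been measured in an ADME assay on cells for inhibition of cytochrome P450 11B1, mitochondrial (Homo sapiens), read by HPLC, with a stated time of 60 min; on this read-out higher numbers stand for weaker inhibition and lower numbers for stronger inhibition:

compound 1 `Fc1ccc2nc(-n3ccnn3)n(C3CC3)c2c1` gives 9070 nM
compound 2 `Fc1ccc2nc(-c3cn[nH]c3)n(C3CC3)c2c1` gives 1670 nM
compound 3 `Fc1ccc2nc(-c3cnccn3)n(C3CC3)c2c1` gives > 10000 nM, which is a limit of the assay and not a number

Compound 2 stands with the lowest of the two numbers shown; its nearest neighbour is compound 1, and the step of a 5.4-fold lower number from compound 1 to compound 2 (0.73 log units; beyond the scatter) lies beyond the scatter. Compound 3 sits at the limit of > 10000 nM in this assay, at which 1 of the 3 values shown sits.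

The next compound, compound 4 `Fc1ccc2nc(-c3cccnn3)n(C3CC3)c2c1`, differs from compound 2 in one place: pyridazin-3-yl in place of 1H-pyrazol-4-yl on an aromatic carbon. The closest measured comparison is the step of an at least 5.9-fold higher number from compound 2 to compound 3 (0.77 log units; beyond the scatter), where the same five-membered ring was swapped for a six-membered aromatic ring with two hetero atoms and the number rose to the limit. The step of a 5.4-fold lower number from compound 1 to compound 2 (0.73 log units; beyond the scatter) points the same way, in that the five-membered ring bearing a hydrogen-bond donor gave the lowest number of the three.

On this basis the swap to pyridazin-3-yl is expected to weaken inhibition, with a step of about a 4.8-fold higher number from compound 2 to compound 4 (0.68 log units; beyond the scatter) in this assay. Compound 4 is therefore estimated at 8000 nM, in a range from 2500 nM to 30000 nM, with a fair chance that only a limit is reported.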

Compound 4, half-maximal inhibitory concentration: > 10000 nM
Compound 4: only a limit was reported (the forecaster's own chance of this, stated with the estimate: 40%); middle value at least 1.2-fold (0.09 log units) away from the limit.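

In this assay, putting pyridazin-3-yl in place of 1H-pyrazol-4-yl gives an at least 5.9-fold higher number from compound 2 to compound 4 (0.77 log units; beyond the scatter), so pyrazin-2-yl is no lone case: a second six-membered aromatic ring with 2 hetero atoms also ends well away from compound 2 at this position. Against the triazole the result is less sharp, with an at least 1.1-fold higher number from compound 1 to compound 4 (0.04 log units; that floor lies within the scatter), and this floor alone does not separate the two compounds. The step between the two six-membered rings cannot be read, so they cannot be ranked against each other, and both end at the same limit of the assay: the limit of > 10000 nM in this assay, at which 2 of the 4 values shown sit.

As far as these compounds go, whether the lower number of compound 2 goes with its ring size or with its ring hydrogen stays open; compound 1 also carries a five-membered aromatic ring, yet gives 9070 nM, and so goes against any rule based on ring size alone. A 1-methylpyrazol-4-yl group, with a methyl group in place of that hydrogen, and a plain phenyl ring, with carbon atoms only, would help to separate these two readings.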